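From Chloro to Fluoro on a Hydrazone Arm

A few compounds are considered here, and "the series" means these few. Any claim that something is new, unique, unknown or untested is made for them only; others in the source may bear on it.

This study measures growth inhibition of liver cancer cells in a functional assay on HepG2 cells (Homo sapiens) for inhibition, read by MTT assay, with a stated time of 72 h; on this read-out higher numbers stand for weaker inhibition and lower numbers for stronger inhibition. Compound 1 `CNc1nc(C)c(C(=O)N/N=C/c2cccc(C(F)(F)F)c2)s1` reaches only the assay's limit, > 100 ug/mL, which is a limit rather than a number. Compound 3 `CN(C(=O)NC(=O)c1cccc(C(F)(F)F)c1)c1nc(C(F)(F)F)c(C(=O)N/N=C/c2cc(C(F)(F)F)cc(C(F)(F)F)c2)s1` gives 5.38 ug/mL. Compound 2 `Cc1nc(N(C)C(=O)NC(=O)c2c(F)cccc2F)sc1C(=O)N/N=C/c1ccccc1Cl` likewise reaches only a limit, > 100 ug/mL, and so it stands with the majority of results here, as seen in the limit of > 100 ug/mL in this assay, at which 2 of the 3 values shown sit. Compound 4 `Cc1nc(N(C)C(=O)NC(=O)c2c(F)cccc2F)sc1C(=O)N/N=C/c1ccccc1F` is not yet measured. It differs from compound 2 by fluoro in place of chloro on an aromatic carbon. Among the compounds with values here, no measured pair in this set shows a step of this kind, so no size can be read from the data. A swap of one halogen for another is expected to leave the result within the usual scatter, giving an expected step that the limit leaves unreadable from compound 2 to compound 4 of no real size. Compound 4 is therefore estimated at 150 ug/mL, between 60 ug/mL and 400 ug/mL, and most likely again only a limit.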

Compound 4, half-maximal inhibitory concentration: > 100 ug/mL
Compound 4: no number, only a limit (the forecaster's own chance of this, stated with the estimate: 80%); the middle value does not contradict the limit.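

Within the data shown here, compound 2 and compound 4 each reach only a limit of the assay, not a number, so no step from chloro to fluoro can be read between them. The compounds shown leave open whether this swap changes the inhibition of these cells at all.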